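The compounds below may be only part of what the source reports. "The series", "measured", "known", "first", "only" and "open" are said of these compounds alone.

Of the compounds shown here, three built on the shared core have so far been measured in a functional assay on KG-1 cells (Homo sapiens) for antiproliferative activity; on this read-out higher numbers stand for an effect only at larger amounts of compound and lower numbers for an effect already at smaller amounts. Compound 1 `NC(=O)c1cc(Cl)c2c(Cl)c(C#CCO)n([C@H]3CCCNC3)c2n1` gives 301 nM. Compound 2 `CN1CC(C#Cc2c(Cl)c3c(Cl)cc(C(N)=O)nc3n2[C@H]2CCCNC2)CC1=O` gives 155 nM, and compound 3 `NC(=O)c1cc(Cl)c2c(Cl)c(C#CCN3CCCC3=O)n([C@H]3CCCNC3)c2n1` gives 178 nM. Compound 2 carries the lowest of the three numbers, yet neither neighbour is separated from it beyond the scatter: a 1.9-fold lower number from compound 1 to compound 2 (0.29 log units; within the scatter) and a 1.1-fold higher number from compound 2 to compound 3 (0.06 log units; within the scatter). The third pair behaves the same way, a 1.7-fold lower number from compound 1 to compound 3 (0.23 log units; within the scatter).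

Compound 4 `CC(C)(CC#Cc1c(Cl)c2c(Cl)cc(C(N)=O)nc2n1[C@H]1CCCNC1)C(N)=O` is the next member and has not yet been measured in this assay. Relative to compound 2 the change is 2-carbamoyl-2-methylpropyl in place of 1-methyl-5-oxopyrrolidin-3-yl on a triple-bonded carbon. All three measured steps exchange the group on the triple-bonded carbon, and every one of them stays within the scatter, so a fourth exchange at the same place is expected to behave alike. The step of a 1.3-fold higher number from compound 2 to compound 4 (0.11 log units; within the scatter) is therefore expected to stay within the scatter. For compound 4 a value of 200 nM is estimated, with a range from 90 nM to 450 nM.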

Compound 4, half-maximal effective concentration: 269 nM
Compound 4: middle estimate off by 1.3-fold (0.13 log units), on the low side, and the stated range covers the measured number.
By their numbers in this assay, from the lowest: compounds 2, 3, 4 and 1 (each within the scatter of the next).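

In this assay, 2-carbamoyl-2-methylpropyl on a triple-bonded carbon has no ring and 1 hydrogen-bond donor, while 1-methyl-5-oxopyrrolidin-3-yl has one five-membered non-aromatic ring and 0 hydrogen-bond donors, yet with the same 7 heavy atoms this exchange gives a 1.7-fold higher number from compound 2 to compound 4 (0.24 log units; within the scatter). The other new steps, a 1.5-fold higher number from compound 3 to compound 4 (0.18 log units; within the scatter) and a 1.1-fold lower number from compound 1 to compound 4 (0.05 log units; within the scatter), also stay within the scatter, so among these four compounds neither the ring nor the added donor separates any compound from the others, and an open chain with a carbamoyl group is tolerated here. No measurement is available that would explain this flat response.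

As far as these compounds go, whether any group at this place can move the number beyond the scatter remains open, for example a carboxylic acid, a dimethylamino group or a longer chain. Also open, from the compounds shown here alone, is whether the carbamoyl group itself matters, which a comparison with the plain 2,2-dimethylpropyl chain would address.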